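Working notes: nitro in place of vinyl, compound 4

The compounds below may be only part of what the source reports. "The series", "measured", "known", "first", "only" and "open" are said of these compounds alone.

Measured in an ADME assay on PC-3 cells (Homo sapiens) for cytotoxicity, read by WST assay, tested at 100 uM; a higher number here means more inhibition at the concentration tested (going by the name of the read-out), a lower number less inhibition:
compound 1 `O=C(Nc1cccc(Oc2nccc(C(F)(F)F)c2Cl)c1)C1CCCN(C(=O)c2cc(C(F)(F)F)cc(C(F)(F)F)c2)C1`: 0%
compound 2 `C=Cc1cccc(C(=O)N2CCCC(C(=O)Nc3ccc(Cl)cc3)C2)c1`: 0%
compound 3 `Cc1nc(-c2cccc(NC(=O)C3CCCN(C(=O)c4cc(C(F)(F)F)cc(C(F)(F)F)c4)C3)c2)cs1`: 1%

Compound 2 stands level with compound 1 at the digits shown, the two together the lowest of the three numbers; compound 3 lies a little higher, within the scatter, so all three read as essentially no inhibition. Going by the values given here, the one measured single-point step, a number 1 percentage points higher from compound 1 to compound 3 (within the scatter), was within the scatter and concerned a different position on the shared core. Compound 4 `O=C(Nc1ccc(Cl)cc1)C1CCCN(C(=O)c2cccc([N+](=O)[O-])c2)C1` differs from compound 2 by nitro in place of vinyl on an aromatic carbon. Among the compounds with values here, no measured step bears directly on this change, so the expectation rests on the flat picture so far: a step of no change at the digits printed from compound 2 to compound 4 (within the scatter) is expected, none beyond the scatter. Compound 4 is therefore estimated at 0%, within -5% to 10%.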

Compound 4, a percentage reported as inhibition, at one concentration (the size of the read-out at that concentration, not a potency): 0%
For compound 4 middle estimate and measured number coincide at the digits printed, and the stated range covers the measured number.
By their numbers in this assay, from the lowest: compounds 1, 2, 4 and 3 (each within the scatter of the next).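

In this assay the position on the aromatic carbon meta to a large group now has its first measured step: 3-vinylphenyl to 3-nitrophenyl gives no change at the digits printed from compound 2 to compound 4 (within the scatter) and so leaves the reading unmoved. At this position, then, a nitro group with hydrogen-bond acceptors reads the same as a vinyl group with none. Nothing measured here explains this flat reading.

Only these two groups have been compared at this position, so the reading cannot yet be generalised to other substituents. As far as these compounds go, whether an amine, a carboxylic acid or a longer chain there would give a different reading stays open.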